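Fluoro to Methyl on Compound 3: Expecting Compound 4

The compounds below may be only part of what the source reports. "The series", "measured", "known", "first", "only" and "open" are said of these compounds alone.

Compound 1, `O=C1c2cc(COc3ccccc3)nn2CCN1c1ccccn1`, gives 69% in a functional assay on HEK293 cells for positive allosteric modulation of metabotropic glutamate receptor 5 (Homo sapiens), read by calcium flux; on this read-out lower numbers stand for smaller maximal responses and higher numbers for larger maximal responses.
Compound 2, `O=C1c2cc(COc3ccccc3)nn2CCN1c1ccncc1`, gives 72% in this assay.
Compound 3, `O=C1c2cc(COc3ccccc3)nn2CCN1c1ccc(F)cn1`, gives 72% in this assay.

Compound 3 stands level with compound 2 at the digits printed, and the two share the highest number of the three. The remaining step is a number 3 percentage points higher from compound 1 to compound 3 (within the scatter), so all three compounds sit inside the usual scatter of one another and none can be called stronger than the others.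

Compound 4, `Cc1ccc(N2CCn3nc(COc4ccccc4)cc3C2=O)nc1`, differs from compound 3 by methyl in place of fluoro on an aromatic carbon. The same difference, cut one bond further out, reads 5-fluoropyridin-2-yl to 5-methylpyridin-2-yl.

Only the measured step at this very position bears on the change: a number 3 percentage points higher from compound 1 to compound 3 (within the scatter). Putting fluoro there in place of hydrogen left the maximal response within the scatter, and changing the whole ring as in no change at the digits printed from compound 2 to compound 3 (within the scatter) did the same. Going by the values given here, no measured step involves methyl, so the expectation rests on the ring position having tolerated substitution so far. In this assay compound 4 is therefore expected to give 72%, within a range from 60% to 84%. That amounts to an expected step of no change at the digits printed from compound 3 to compound 4 (within the scatter), that is, no change beyond the scatter.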

Compound 4, largest response reached (Emax), in percent of the reference or control that the assay uses: 76%
For compound 4 the middle estimate is 4 percentage points below the measured one; the measured number falls inside the stated range.
By their numbers in this assay, from the lowest: compounds 1, 2, 3 and 4 (each within the scatter of the next).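

Methyl now joins fluoro as a group seen on this aromatic carbon, two atoms from the ring nitrogen, and in this assay exchanging one for the other gives a number 4 percentage points higher from compound 3 to compound 4 (within the scatter) and so leaves the maximal response unresolved from that of the fluoro compound. Measured against the unsubstituted ring, methyl in place of hydrogen gives a number 7 percentage points higher from compound 1 to compound 4 (within the scatter) and measured against the pyridin-4-yl ring, the 5-methylpyridin-2-yl ring gives a number 4 percentage points higher from compound 2 to compound 4 (within the scatter) so that all four compounds still cannot be told apart, now with a carbon group at this position as well as fluoro. Nothing available offers an explanation for why these numbers sit so close together.

What the compounds shown leave open is where this flat picture ends, since an ethyl, a methoxy, an amine or a carboxylic acid at this carbon might or might not keep the maximal response in the same range. From the compounds shown here alone, it is also open whether methyl would behave the same way on the pyridin-4-yl ring of compound 2, where only the unsubstituted form appears here.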